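The source may report more compounds than this note shows. Statements on the series, on what has been measured and on what is new or still open speak of the compounds shown alone.

Measured so far: compound 1 `CC(C)CCn1ccc(N2CCN(c3ccccn3)CC2)c(C#N)c1=O` gives 3090 nM, compound 2 `CCCCn1ccc(N2CCC(c3ccccc3)CC2)c(C#N)c1=O` gives 95 nM, and compound 3 `CC(C)Cn1ccc(N2CCC(c3ccccc3)CC2)c(C#N)c1=O` gives 282 nM, all in a functional assay on CHO cells for positive allosteric modulation of metabotropic glutamate receptor 2 (Homo sapiens), with a stated time of 30 min; a lower number here means that less compound is needed, a higher number that more compound is needed for the effect.

Compound 3 stands second highest of the three numbers in this assay, with compound 2 nearest and compound 1 furthest. Compound 4 `N#Cc1c(N2CCC(c3ccccc3)CC2)ccn(CCC2CC2)c1=O` differs from compound 3 by cyclopropylmethyl in place of isopropyl on a saturated chain carbon bound to an aromatic nitrogen. Among the compounds with values here, the one measured step at this place is a 3.0-fold higher number from compound 2 to compound 3 (0.47 log units; beyond the scatter), where branching beside the chain carbon raised the number. Compound 4 undoes that branching and lengthens the chain, so the number is expected to move back toward compound 2, giving an expected 2.0-fold lower number from compound 3 to compound 4 (0.30 log units; within the scatter). Compound 4 is therefore estimated at 140 nM, with a range of 50 nM to 400 nM.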

Compound 4, half-maximal effective concentration: 178 nM
The estimate for compound 4 lay 1.3-fold (0.10 log units) below the measured number, and the stated range covers the measured number.
By their numbers in this assay, from the lowest: compounds 2, 4 and 3 (each within the scatter of the next, the first and the last beyond it); then compound 1.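

Compound 4 carries a three-membered ring at this place, on a saturated chain carbon bound to an aromatic nitrogen, and in this assay its number cannot be separated from either neighbour: a 1.6-fold lower number from compound 3 to compound 4 (0.20 log units; within the scatter), and a 1.9-fold higher number from compound 2 to compound 4 (0.27 log units; within the scatter). Those two neighbours do stand apart, with a 3.0-fold higher number from compound 2 to compound 3 (0.47 log units; beyond the scatter), so the cyclopropyl ring gives a number that sits within the scatter of both.

From the compounds shown here alone, whether a longer chain or a benzyl group at this place would give a number outside that span stays open. Nothing shown gives a reason for these numbers.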